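A few compounds are considered here, and "the series" means these few. Any claim that something is new, unique, unknown or untested is made for them only; others in the source may bear on it.

Measured so far: compound 1 `COc1cc2c(cc1OC)CN(CCCCNC(=O)c1ccc(-c3cn(CCOCCF)nn3)cc1)CC2` gives 14700 nM in an assay on membranes from brain for displacement of a labelled ligand from Sigma non-opioid intracellular receptor 1 (Cavia porcellus), read by scintillation counting, with a stated time of 90 min (a higher number here means a weaker inhibitor, a lower number a stronger inhibitor), and compound 2 `COc1cc2c(cc1OC)CN(CCCCNC(=O)c1ccc(-c3cn(CCOCCOCCF)nn3)cc1)CC2` gives 16000 nM.

Compound 2 stands with the highest of the two numbers in this assay, yet its nearest neighbour, compound 1, is separated from it only by a 1.1-fold higher number from compound 1 to compound 2 (0.04 log units; within the scatter), a step that stays within the scatter. Compound 3 `COc1ccccc1Cn1cc(-c2ccc(C(=O)NCCCCN3CCc4cc(OC)c(OC)cc4C3)cc2)nn1` differs from compound 2 by 2-methoxyphenyl in place of (2-(2-fluoroethoxy)ethoxy)methyl on a saturated chain carbon bound to an aromatic nitrogen. Going by the values given here, no measured step bears directly on this change: the only step recorded, from compound 1 to compound 2, alters the length of the fluorinated chain and leaves the number essentially unchanged, whereas the step to compound 3 removes that chain altogether and brings in a ring. The expectation for compound 3 in this assay is therefore uncertain, and a modest step downward, a 2.7-fold lower number from compound 2 to compound 3 (0.43 log units; beyond the scatter), is estimated. Compound 3 is expected to give about 6000 nM, within a range of 1500 nM to 25000 nM.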

Compound 3, inhibition constant: 8580 nM
For compound 3 the middle estimate is 1.4-fold (0.16 log units) below the measured one; low and high end bracket the measured number.
By their numbers in this assay, from the lowest: compounds 3, 1 and 2 (each within the scatter of the next).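

Until now, only the length of the fluorinated ether chain had been varied at this position. Compound 3 puts a ring there: with 2-methoxyphenyl on the saturated chain carbon bound to an aromatic nitrogen, this assay gives a 1.9-fold lower number from compound 2 to compound 3 (0.27 log units; within the scatter), and against the shorter chain it gives a 1.7-fold lower number from compound 1 to compound 3 (0.23 log units; within the scatter). Even this exchange of an open ether chain for an aromatic ring of the same heavy-atom count therefore does not separate the three compounds, all of which remain in one band of weak numbers. Nothing available explains this result.

As far as these compounds go, it remains open whether any group at this place can move the number beyond the scatter. An amine or a carboxylic acid on the chain, or a ring without the methoxy group, would test this.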